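This account rests on a few compounds, and the source may have more. Where it says the series, first, only, none or still open, it means among the compounds named here.

Working notes on the series. Compound 1 `CN(C)CCn1cnnc1-c1cc(Oc2ccc(NC(=O)N/N=C/c3ccc(F)cc3)cc2F)ccn1` is the reference: in a functional assay on U-87MG ATCC cells (Homo sapiens) for cytotoxicity, read by MTT assay, with a stated time of 72 h (a lower number here means a stronger inhibitor, a higher number a weaker inhibitor), compound 1 gives 2310 nM. Compound 2 `COc1ccc(/C=N/NC(=O)Nc2ccc(Oc3ccnc(-c4nncn4CCN(C)C)c3)c(F)c2)cc1O` carries 3-hydroxy-4-methoxyphenyl on the carbon with a double bond to nitrogen; in this assay compound 2 reaches only the limit > 100000 nM. Compound 3 `COc1cc(/C=N/NC(=O)Nc2ccc(Oc3ccnc(-c4nncn4CCN(C)C)c3)c(F)c2)ccc1O` carries 4-hydroxy-3-methoxyphenyl at the same place; in this assay compound 3 likewise reaches only the limit > 100000 nM. Both replacements cost heavily: an at least 43-fold higher number from compound 1 to compound 2 (1.63 log units; beyond the scatter), and an at least 43-fold higher number from compound 1 to compound 3 (1.63 log units; beyond the scatter). The step between the two hydroxy-methoxy isomers cannot be read, a step that the two limits leave unreadable from compound 2 to compound 3, since both sit at the limit (the limit of > 100000 nM in this assay, at which 2 of the 3 values shown sit).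

Compound 4 `CN(C)CCn1cnnc1-c1cc(Oc2ccc(NC(=O)N/N=C/c3ccc(O)cc3O)cc2F)ccn1` is the next member, not yet measured: 2,4-dihydroxyphenyl in place of 4-hydroxy-3-methoxyphenyl on a carbon with a double bond to nitrogen. The two measured steps that bear on it, from compound 1 to compound 2 and from compound 1 to compound 3, both show that exchanging 4-fluorophenyl for a hydroxylated, oxygen-substituted phenyl at this carbon removes measurable activity. The change to compound 4 keeps a phenyl bearing two oxygen substituents, one of them again a hydroxy group, so no recovery is expected; the step of a number no higher from compound 3 to compound 4 (the limit leaves the size open) is expected to be unreadable or flat. Compound 4 is therefore estimated at 100000 nM in this assay, with a range from 20000 nM to 300000 nM, and most likely reported only as a limit.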

Compound 4, half-maximal inhibitory concentration: 15400 nM
Compound 4: the middle estimate sits 6.5-fold (0.81 log units) above what was measured, and the stated range ends above it.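

In this assay, the carbon with a double bond to nitrogen turns out to accept a phenyl bearing two oxygen substituents and still give a readable value: 2,4-dihydroxyphenyl gives an at least 6.4-fold lower number from compound 3 to compound 4 (0.81 log units; beyond the scatter), and likewise an at least 6.4-fold lower number from compound 2 to compound 4 (0.81 log units; beyond the scatter). The earlier compounds shown here suggested that any hydroxylated phenyl here loses measurable activity, but compound 4 goes against that reading, so the outcome depends on which oxygen substituents the phenyl carries and not merely on the presence of a hydroxy group. The recovery is only partial, as 4-fluorophenyl remains ahead with a 6.7-fold higher number from compound 1 to compound 4 (0.82 log units; beyond the scatter).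

Going by these compounds, the full size of the gain over the two hydroxy-methoxy isomers stays open, because compound 2 and compound 3 each rest on a limit and not on a number: the limit of > 100000 nM in this assay, at which 2 of the 4 values shown sit. Also open is whether the gain follows the second hydroxy group or the absence of the methoxy group, a question that 2-hydroxyphenyl, 4-hydroxyphenyl or 4-aminophenyl on the same carbon would address.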